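Substituent on the shared core and Vero cytotoxicity

The source may report more compounds than this note shows. Statements on the series, on what has been measured and on what is new or still open speak of the compounds shown alone.

Compound 1 `CNC1=C([N+](=O)[O-])C(c2ccc(N3CCN(c4ccnc5cc(Cl)ccc45)CC3)cc2)c2ccccc2O1` gives in an ADME assay on Vero cells (Chlorocebus sabaeus) for cytotoxicity, read by MTT assay, with a stated time of 72 h (a lower number here means that less compound is tolerated, a higher number that more compound is tolerated), a value that is a limit of the assay: > 200000 nM.
Compound 2 `CNC1=C([N+](=O)[O-])C(c2ccc(N3CCN(c4ccnc5cc(Cl)ccc45)CC3)cc2)c2cc(Cl)ccc2O1` gives 74500 nM.
Compound 3 `CNC1=C([N+](=O)[O-])C(c2ccc(N3CCN(c4ccnc5cc(Cl)ccc45)CC3)cc2)c2cc(Br)ccc2O1` gives 88600 nM.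

Compound 3 stands highest of the two numbers; the step of a 1.2-fold higher number from compound 2 to compound 3 (0.08 log units; within the scatter) lies within the scatter. Compound 4 `CNC1=C([N+](=O)[O-])C(c2ccc(N3CCN(c4ccnc5cc(Cl)ccc45)CC3)cc2)c2cc([N+](=O)[O-])ccc2O1` differs from compound 3 by nitro in place of bromo on an aromatic carbon. The steps of an at least 2.6-fold lower number from compound 1 to compound 2 (0.42 log units; beyond the scatter) and an at least 2.2-fold lower number from compound 1 to compound 3 (0.35 log units; beyond the scatter) show that chloro or bromo on this carbon gives a lower number than hydrogen, though compound 1 sits at the limit (the limit of > 200000 nM in this assay, at which 1 of the 3 values shown sits). The step of a 1.2-fold higher number from compound 2 to compound 3 (0.08 log units; within the scatter) shows that exchanging one such group for the other changes little. Among the compounds with values here, no measured step covers nitro. The step of a 1.1-fold lower number from compound 3 to compound 4 (0.04 log units; within the scatter) is therefore expected to stay within the scatter. Compound 4 is estimated at 80000 nM, with a range from 30000 nM to 200000 nM.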

Compound 4, half-maximal cytotoxic concentration: 31900 nM
Estimate against measurement, compound 4: 2.5-fold (0.40 log units) above, within the range that was stated.
By their numbers in this assay, from the lowest: compound 4; then compounds 2 and 3 (each within the scatter of the next). At a limit, above all of these: compound 1.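

In this assay, nitro on this aromatic carbon separates from the two halogens, which chloro and bromo could not show between themselves: a 2.8-fold lower number from compound 3 to compound 4 (0.44 log units; beyond the scatter) and a 2.3-fold lower number from compound 2 to compound 4 (0.37 log units; beyond the scatter). The group entering here therefore matters beyond simply replacing hydrogen, and against hydrogen the step is an at least 6.2-fold lower number from compound 1 to compound 4 (0.79 log units; beyond the scatter). That last step is only a bound, as the value of compound 1 is a limit: the limit of > 200000 nM in this assay, at which 1 of the 4 values shown sits.

Going by these compounds, whether an amine, a carboxylic acid or a methoxy group on this carbon would follow nitro or the halogens stays open. On these data alone, how the same groups behave on the other carbons of this ring also stays open.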